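Swapping an Amino Side Chain for a Fused Ring

A few compounds are considered here, and "the series" means these few. Any claim that something is new, unique, unknown or untested is made for them only; others in the source may bear on it.

Among the compounds with values here, compound 2 `CCN(Cc1cccnc1)c1cccc(C(=O)N2CCc3ccc(OS(N)(=O)=O)cc3C2)c1` gives 33.5% in an assay on HEK293 cells for inhibition of Steryl-sulfatase (Homo sapiens), tested at 1 uM (a higher number here means a stronger effect of the compound at the concentration tested, a lower number a weaker effect), the lower of the two numbers measured so far; the nearest is compound 1 `CCN(Cc1ccncc1)c1cccc(C(=O)N2CCc3ccc(OS(N)(=O)=O)cc3C2)c1`, which gives 52.8%. Within the data shown here, the single measured step, a number 19.3 percentage points lower from compound 1 to compound 2 (beyond the scatter), shows how much a small change can move this read-out. Compound 3 `NS(=O)(=O)Oc1ccc2c(c1)CN(C(=O)c1cccc(N3CCc4ccccc4C3)c1)CC2` differs from compound 2 by 1,2,3,4-tetrahydroisoquinolin-2-yl in place of ethyl((pyridin-3-yl)methyl)amino on an aromatic carbon. Among the measured compounds shown here, no measured step involves this kind of change, so its direction is unknown, and a move of the same order as the one known step seems possible either way. Compound 3 is therefore expected to give 40% (from 15% to 70%), an expected step of a number 6.5 percentage points higher from compound 2 to compound 3 (within the scatter).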

Compound 3, a percentage reported as inhibition, at one concentration (the size of the read-out at that concentration, not a potency): 50.2%
Compound 3: middle estimate off by 10.2 percentage points, on the low side, within the range that was stated.
By their numbers in this assay, from the lowest: compound 2; then compounds 3 and 1 (each within the scatter of the next).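

Putting 1,2,3,4-tetrahydroisoquinolin-2-yl in place of ethyl((pyridin-3-yl)methyl)amino on this aromatic carbon gives, in this assay, a number 16.7 percentage points higher from compound 2 to compound 3 (beyond the scatter). Against ethyl((pyridin-4-yl)methyl)amino, the same fused ring gives a number 2.6 percentage points lower from compound 1 to compound 3 (within the scatter), so at this position a side chain with a pyridine ring is not needed to match the better of the two open chains. Nothing measured here explains either step.

As far as these compounds go, whether either ring of the fused group matters stays open. A plain piperidine or morpholine ring on this carbon would begin to test that.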